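Swapping the ring-nitrogen group: from compound 1 to compound 4

The source may hold more compounds than are shown below. What is called first, only, known or untested is meant among the compounds shown, and "the series" means these compounds.

Measured compounds:
compound 1 `O=C(/C=C/c1ccccc1)c1ccc(N2CCN(c3ccccc3F)CC2)cc1`, 0.57%
compound 2 `COc1ccc(N2CCN(c3ccc(C(=O)/C=C/c4ccc(Cl)cc4)cc3)CC2)cc1`, 55.1%
compound 3 `O=C(/C=C/c1ccc(Cl)cc1)c1ccc(N2CCN(S(=O)(=O)c3ccc(Cl)cc3)CC2)cc1`, 56.6%

All three were tested in a functional assay on the whole organism (strain Kunming) for inhibition, with Mus musculus as the target, with a stated time of 1 h, at a dose of 40 mg/kg by the oral route; on this read-out lower numbers stand for less inhibition and higher numbers for more inhibition at the one dose given (going by the name of the read-out). Compound 1 stands lowest of the three: compound 2 lies far higher, and compound 3 higher still, both gaps beyond the scatter. Compound 2 and compound 3 also differ from compound 1 in a second place, so their gap to compound 1 cannot be traced to one change alone.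

Compound 4 `Cc1ccc(S(=O)(=O)N2CCN(c3ccc(C(=O)/C=C/c4ccccc4)cc3)CC2)cc1` has not yet been measured. It differs from compound 1 in one place: (4-methylphenyl)sulfonyl in place of 2-fluorophenyl on an amine nitrogen in a ring. For the measured compounds named here, the one measured step on that same ring nitrogen is a number 1.5 percentage points higher from compound 2 to compound 3 (within the scatter), which shows that exchanging an aryl group for an arylsulfonyl group there changed little. That step, however, was taken from a high starting point, whereas compound 1 starts near zero, so the outcome is uncertain.

A rise of a number 29.4 percentage points higher from compound 1 to compound 4 (beyond the scatter) is expected. Compound 4 is estimated at 30%, within a range from 3% to 60%.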

Compound 4, a percentage reported as inhibition, in the whole organism at one dose (the size of the read-out at that dose, not a potency): 30.8%
Beside the measured number, compound 4's estimate is 0.8 percentage points below it; measured number inside the range.
By their numbers in this assay, from the lowest: compound 1; then compound 4; then compounds 2 and 3 (each within the scatter of the next).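

In this assay, the ring nitrogen turns out to be a place where a change can count for a lot: putting the new group there gives a number 30.2 percentage points higher from compound 1 to compound 4 (beyond the scatter). The earlier change at this nitrogen, with a number 1.5 percentage points higher from compound 2 to compound 3 (within the scatter), showed no such effect, but it involved different leaving and entering groups on a different remainder of the molecule, so a move to an arylsulfonyl group has no single size across the compounds shown. No measurement here explains the rise.

The compounds shown do not tell whether the rise goes with the sulfonyl link or with the methyl on its ring. From the compounds shown here alone, how a methylsulfonyl or an acetyl group on this ring nitrogen would read in this assay also remains open.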